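The source may hold more compounds than are shown below. What is called first, only, known or untested is meant among the compounds shown, and "the series" means these compounds.

Compound 3 `Cc1nc(Cn2c(=O)[nH]c3c(N)nc(C(F)(F)F)cc32)cs1` is known in an ADME assay on cytosol (Rattus norvegicus) for metabolic stability (a higher number here means that the compound lasts longer, a lower number that the compound disappears faster), only through a limit, > 16.6 h. Compound 2 `Cc1cc(Cn2c(=O)[nH]c3c(N)nc(C(F)(F)F)cc32)no1` also reaches a limit in this assay, > 16.6 h. For the measured compounds named here, compound 1 `Cc1ccc(Cn2c(=O)[nH]c3c(N)nc(C(F)(F)F)cc32)nc1` is the only member with a read number, giving 1.38 h in this assay. The steps of an at least 12-fold higher number from compound 1 to compound 2 (1.08 log units; beyond the scatter) and an at least 12-fold higher number from compound 1 to compound 3 (1.08 log units; beyond the scatter) are both large, whereas a step that the two limits leave unreadable from compound 2 to compound 3 cannot be read because both of its ends sit at the limit of > 16.6 h in this assay, at which 2 of the 3 values shown sit. Compound 4 `Cc1nc(Cn2c(=O)[nH]c3c(N)nc(C(F)(F)F)cc32)co1` differs from compound 3 by 2-methyl-1,3-oxazol-4-yl in place of 2-methyl-1,3-thiazol-4-yl on a saturated chain carbon bound to an aromatic nitrogen. The 5-methyl-1,2-oxazol-3-yl analogue, compound 2, sits at the limit with > 16.6 h. Compound 4 is therefore expected to keep a long half-life, and the step of an at least 1.0-fold lower number from compound 3 to compound 4 (0.01 log units; that floor lies within the scatter) is expected to stay within the scatter. Compound 4 is estimated at 16 h, between 5 h and 40 h, most likely reported again only as a limit.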

Compound 4, half-life: > 16.6 h
Compound 4: no number, only a limit (the forecaster's own chance of this, stated with the estimate: 60%); middle value at least 1.0-fold (0.01 log units) from the limit.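

In this assay compound 4 gives > 16.6 h, which is a limit and not a number. The 2-methyl-1,3-oxazol-4-yl group thus joins the two other five-membered aromatic rings at this limit, and an at least 12-fold higher number from compound 1 to compound 4 (1.08 log units; beyond the scatter) is large, leaving the 5-methylpyridin-2-yl of compound 1 as the one exception among the compounds shown. The steps among compound 2, compound 3 and compound 4 cannot be read, all their ends sitting at one limit: the limit of > 16.6 h in this assay, at which 3 of the 4 values shown sit.

Going by these compounds, how far these three compounds lie apart remains open. Also open, on these data alone, is whether a phenyl ring on the same chain carbon, or an amine in place of the methyl, would stay at this limit.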